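Ethynyl for Phenyl on a Nucleoside Core

The source may report more compounds than this note shows. Statements on the series, on what has been measured and on what is new or still open speak of the compounds shown alone.

Three compounds of one nucleoside series were tested in a functional assay on HL-60 cells (Homo sapiens) for antiproliferative activity, read by XTT assay, with a stated time of 72 h; on this read-out lower numbers stand for stronger inhibition and higher numbers for weaker inhibition. Compound 1 `C#Cc1cn([C@@H]2O[C@H](CO)[C@@H](O)[C@H]2O)c2ncnc(NC)c12` bears an ethynyl group on its core and a methylamino group, and in this assay compound 1 gives 9060 nM. Compound 3 `CNc1ncnc2c1c(-c1ccccc1)cn2[C@@H]1O[C@H](CO)[C@@H](O)[C@H]1O` carries a phenyl group in place of the ethynyl group; its value in this assay is a limit of the assay, > 20000 nM. Compound 2 `COc1ncnc2c1c(-c1ccccc1)cn2[C@@H]1O[C@H](CO)[C@@H](O)[C@H]1O` has the same phenyl group but a methoxy group where compound 3 has methylamino. In this assay compound 2 likewise gives a limit of the assay, > 20000 nM.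

The change from compound 3 to compound 1 is ethynyl in place of phenyl on an aromatic carbon, and it produced an at least 2.2-fold lower number from compound 3 to compound 1 (0.34 log units; beyond the scatter). The two cores of compound 2 and compound 3 differ by methoxy in place of methylamino on an aromatic carbon, which gave a step that the two limits leave unreadable from compound 2 to compound 3, since the limit of > 20000 nM in this assay, at which 2 of the 3 values shown sit, leaves the size of that step open.

Compound 4 `C#Cc1cn([C@@H]2O[C@H](CO)[C@@H](O)[C@H]2O)c2ncnc(OC)c12` is not yet measured. It arises from compound 2 by ethynyl in place of phenyl on an aromatic carbon, the same change that turned compound 3 into compound 1. For compound 4 a step of about an at least 1.3-fold lower number from compound 2 to compound 4 (0.12 log units; that floor lies within the scatter) is expected in this assay. That expectation rests on the step of an at least 2.2-fold lower number from compound 3 to compound 1 (0.34 log units; beyond the scatter) seen for the same change. It rests also on the value of compound 2, which is a limit, > 20000 nM. Compound 4 is therefore estimated at about 15000 nM, with a likely range from 6000 nM to 40000 nM, and a fair chance that this assay again reports only a limit.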

Compound 4, half-maximal inhibitory concentration: 190 nM
Compound 4: middle estimate off by 79-fold (1.90 log units), on the high side; measured number outside the range, below it.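

In this assay, ethynyl in place of phenyl gave an at least 100-fold lower number from compound 2 to compound 4 (2.02 log units; beyond the scatter), which is much the largest step in this small set, and with ethynyl kept in place, methoxy in place of methylamino gave a 48-fold lower number from compound 1 to compound 4 (1.68 log units; beyond the scatter). The ethynyl change thus lowered the number in both of its pairs, so its direction carried from one core to the other, but the two sizes cannot be set against each other as measured: the same change on two cores in this assay, an at least 2.2-fold lower number (0.34 log units; beyond the scatter) from compound 3 to compound 1 and an at least 100-fold lower number (2.02 log units; beyond the scatter) from compound 2 to compound 4; the limit leaves it open whether they differ The pairs show no more than that, and the step from compound 2 to compound 3 cannot be read, so the effect of methoxy in place of methylamino is known only with ethynyl present: the limit of > 20000 nM in this assay, at which 2 of the 4 values shown sit.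

The compounds shown leave open whether a nitrile or a longer chain such as propynyl at the same place would keep the low number of compound 4. They also leave open how an ethoxy group or an unsubstituted amine would read in place of the methoxy group of compound 4, and whether any of these steps would look the same in another cell line.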